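The compounds below may be only part of what the source reports. "The series", "measured", "known", "first", "only" and "open" are said of these compounds alone.

Measured in a functional assay on FaDu cells (Homo sapiens) for antiproliferative activity, read by sulforhodamine B assay, with a stated time of 48 h; a lower number here means a stronger inhibitor, a higher number a weaker inhibitor:
- compound 1 `CCCCN(C)C(=O)CCCOc1cc(OC)c(OC)c2oc(-c3ccc(OC)cc3)c(O)c(=O)c12`: > 40000 nM, a limit
- compound 2 `COc1ccc(-c2oc3c(OC)c(OC)cc(OCCCC(=O)NCc4ccccn4)c3c(=O)c2O)cc1`: > 40000 nM, a limit
- compound 3 `CCCCN(C)C(=O)CCCCOc1cc(OC)c(OC)c2oc(-c3ccc(OC)cc3)c(O)c(=O)c12`: 22000 nM

Going by the values given here, compound 3 holds the only number, 22000 nM. The other two values sit at the limit of > 40000 nM in this assay, at which 2 of the 3 values shown sit.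

Compound 4 `COc1ccc(-c2oc3c(OC)c(OC)cc(OCCCCC(=O)NCc4ccccn4)c3c(=O)c2O)cc1` keeps the chain of compound 3 and alters the amide: ((pyridin-2-yl)methyl)amino in place of butyl(methyl)amino on a carbonyl carbon. The same replacement appears in a step that the two limits leave unreadable from compound 1 to compound 2, so no size can be carried over from it. Compound 2, which carries the same ((pyridin-2-yl)methyl)amino group, gives > 40000 nM, which is a limit. The chain change, seen in an at least 1.8-fold lower number from compound 1 to compound 3 (0.25 log units; that floor lies within the scatter), has a floor within the scatter, and an at least 1.8-fold lower number from compound 2 to compound 3 (0.25 log units; that floor lies within the scatter) likewise stays within it at its floor.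

With no readable size for this replacement, no step beyond the scatter is expected in this assay, with only a slight lean toward a higher number. The expected step is a 1.4-fold higher number from compound 3 to compound 4 (0.13 log units; within the scatter). Compound 4 is estimated at 30000 nM, with an expected range of 15000 nM to 50000 nM.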

Compound 4, half-maximal inhibitory concentration: > 40000 nM
Compound 4 was reported as a limit; the forecaster's own chance of this, stated with the estimate: 45%; middle value at least 1.3-fold (0.12 log units) away from the limit.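

In this assay the replacement of butyl(methyl)amino by ((pyridin-2-yl)methyl)amino on the carbonyl carbon can now be read on the longer chain, as an at least 1.8-fold higher number from compound 3 to compound 4 (0.25 log units; that floor lies within the scatter), which gives a direction but no firm size. Going by these compounds alone, the value of compound 4 is a limit, so only a floor is known for this step, and compound 3, with the longer chain and butyl(methyl)amino together, still holds the only number. The steps to compound 4 from compound 1 and from compound 2 cannot be read because both ends of each are limits: the limit of > 40000 nM in this assay, at which 3 of the 4 values shown sit.

Still open, from the compounds shown here alone, is how far the true value of compound 4 lies from that of compound 3. Going by these compounds, it is also open whether a longer chain, or a carboxylic acid in place of the amide, would bring a number within the range of this assay.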